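The source may report more compounds than this note shows. Statements on the series, on what has been measured and on what is new or still open speak of the compounds shown alone.

Working notes on the series, read in an ADME assay on microsomes from liver (Mus musculus) for metabolic stability, read by LC-MS, with a stated time of 10 min; on this read-out higher numbers stand for a more stable compound and lower numbers for a less stable compound. Of the compounds shown here, three have numbers so far, and they differ only in the group on one aromatic carbon of the shared core. Compound 1 `C[C@@H]1CN(c2cccc3c2C[C@H](CN(C)[C@H]2CCCc4cccnc42)NC3)C[C@H](C)N1` gives 85.6%, compound 3 `CN(C[C@H]1Cc2c(cccc2N2C[C@@H]3C[C@H]2CN3)CN1)[C@H]1CCCc2cccnc21` gives 36.3% and compound 2 `CN(C[C@H]1Cc2c(cccc2N2CCN(C3CC3)CC2)CN1)[C@H]1CCCc2cccnc21` gives 7%, the lowest of the three.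

Compound 4 `CN(C[C@H]1Cc2c(cccc2N2CCN(c3ccccn3)CC2)CN1)[C@H]1CCCc2cccnc21` has pyridin-2-yl in place of cyclopropyl on an amine nitrogen in a ring of compound 2: pyridin-2-yl in place of cyclopropyl on an amine nitrogen in a ring.

Among the measured compounds shown here, no measured step makes this exact change. The closest evidence is indirect: a number 78.6 percentage points lower from compound 1 to compound 2 (beyond the scatter) and a number 49.3 percentage points lower from compound 1 to compound 3 (beyond the scatter) are large, and a number 29.3 percentage points higher from compound 2 to compound 3 (beyond the scatter) is modest. Changes in this group have therefore moved this assay far, but none of the three puts an aromatic ring on that nitrogen. Compound 2 at 7% leaves little room downward, so any movement is more likely to be upward.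

The expected change is a number 8 percentage points higher from compound 2 to compound 4 (within the scatter), a small rise that may not clear the scatter. For compound 4 the estimated value is 15%, with an expected range of 3% to 40%.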

Compound 4, percent of the compound remaining: 46.1%
Estimate against measurement, compound 4: 31.1 percentage points below; the measured number lies above the stated range.
By their numbers in this assay, from the lowest: compound 2; then compounds 3 and 4 (each within the scatter of the next); then compound 1.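

In this assay, pyridin-2-yl in place of cyclopropyl on the amine nitrogen in the ring gives a number 39.1 percentage points higher from compound 2 to compound 4 (beyond the scatter), a large step. Among the compounds shown here, the group on that nitrogen alone can therefore move this read-out beyond the scatter while the six-membered non-aromatic ring with 2 nitrogen stays intact, whereas the earlier steps each also altered that ring or its carbons. Nothing available bears on the reason for this step.

Still open, from the compounds shown here alone, is whether the rise depends on the nitrogen within pyridin-2-yl or on the aromatic ring as such, a question that phenyl on the same amine nitrogen would address. Also open, going by these compounds, is where a small group such as methyl or acetyl on that nitrogen would fall relative to cyclopropyl and pyridin-2-yl.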